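Oxazolyl for oxopyrrolidinyl on the amide-side aryl ring

A few compounds are considered here, and "the series" means these few. Any claim that something is new, unique, unknown or untested is made for them only; others in the source may bear on it.

Compound 1 `O=C(Nc1cccc(N2CCCC2=O)c1)C1CCCN(C(=O)c2cc(C(F)(F)F)cc(C(F)(F)F)c2)C1` gives 0% in an ADME assay on PC-3 cells (Homo sapiens) for cytotoxicity, read by WST assay, tested at 100 uM; on this read-out lower numbers stand for less inhibition and higher numbers for more inhibition at the one concentration tested (going by the name of the read-out). Compound 3 `N#Cc1cccc(C(=O)N2CCCC(C(=O)Nc3ccc(Cl)cc3)C2)c1` gives 0% there, level with compound 1 at the digits shown, and the two together sit at the low end of the three numbers. Within the data shown here, compound 2 `O=C(Nc1ccc(Cl)cc1)C1CCCN(C(=O)c2cccc(-c3nccs3)c2)C1` gives 32%, the one number clearly apart from the others. Among the measured compounds shown here, the only step measured within one change is a number 32 percentage points lower from compound 2 to compound 3 (beyond the scatter), a cyano in place of a 1,3-thiazol-2-yl on the acyl-side ring, so an aromatic five-membered heteroaryl group on that side went with more inhibition than the nitrile.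

Compound 4 `O=C(Nc1cccc(-c2cnco2)c1)C1CCCN(C(=O)c2cc(C(F)(F)F)cc(C(F)(F)F)c2)C1` is reached from compound 1 by 1,3-oxazol-5-yl in place of 2-oxopyrrolidin-1-yl on an aromatic carbon. This change sits on the other aryl ring and swaps a non-aromatic lactam for an aromatic heteroaryl, so the measured step carries over only by analogy: a five-membered aromatic group entering went with higher numbers there, but nothing measured speaks to the aniline-side ring directly. A modest rise at most is expected, estimated as a number 10 percentage points higher from compound 1 to compound 4 (within the scatter). Compound 4 is therefore expected to give about 10%, in a range from 0% to 35%.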

Compound 4, a percentage reported as inhibition, at one concentration (the size of the read-out at that concentration, not a potency): 9%
Compound 4: the middle estimate sits 1 percentage points above what was measured; the measured number falls inside the stated range.
By their numbers in this assay, from the lowest: compounds 1, 3 and 4 (each within the scatter of the next); then compound 2.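

In this assay, among these compounds, the first direct reading at this place, meta to a large group on the six-membered aromatic ring, is a number 9 percentage points higher from compound 1 to compound 4 (within the scatter). On the core of compound 1, replacing the non-aromatic 2-oxopyrrolidin-1-yl ring with the aromatic 1,3-oxazol-5-yl ring therefore leaves the read-out within the scatter, so this pair does not show the large step seen on the other aryl ring with 1,3-thiazol-2-yl and cyano. No measurement bearing on the reason for this result is available.

On these data alone, it remains open whether a carboxylic acid or a dimethylamino group at this place would shift the number beyond the scatter. Also open, as far as these compounds go, is whether 1,3-thiazol-2-yl on the acyl-side ring would give a comparable rise on the core of compound 1.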